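This account rests on a few compounds, and the source may have more. Where it says the series, first, only, none or still open, it means among the compounds named here.

Of the compounds shown here, three built on closely related cores have been tested in a functional assay on Vero cells (Chlorocebus sabaeus) for inhibition (on this read-out lower numbers stand for stronger inhibition and higher numbers for weaker inhibition), and none has yielded a number. Compound 1 (`OC[C@H]1O[C@H](n2cnc3c(O)ncnc32)CS1`) reads > 100000 nM, which is a limit of the assay. Compound 2 (`CNc1ncnc2c1ncn2[C@@H]1CS[C@@H](CO)O1`) reads > 100000 nM, again a limit. Compound 3 (`Nc1nc(Cl)c2ncn([C@@H]3CS[C@@H](CO)O3)c2n1`) reads > 100000 nM, also a limit, so its standing is known only as a limit, and the two other values shown are limits too.

Compound 4 (`OC[C@H]1O[C@H](n2cnc3c(Cl)ncnc32)CS1`) has yet to be measured. It follows from compound 3 with hydrogen in place of amino on an aromatic carbon, between two ring nitrogen atoms and meta to a chloro group: hydrogen in place of amino on an aromatic carbon. For the measured compounds named here, the only measured step, a step that the two limits leave unreadable from compound 1 to compound 2, is a different exchange, methylamino in place of hydroxy on an aromatic carbon, and it gives no readable size. The firmest guide is therefore (the limit of > 100000 nM in this assay, at which 3 of the 3 values shown sit). From the compounds shown here alone, no step beyond the usual scatter is expected, and the direction stays open, with the assay quite likely to report a limit again. The expected step is a number no higher from compound 3 to compound 4 (the limit leaves the size open). For compound 4 the estimated value is 100000 nM, with an expected range from 30000 nM to 200000 nM.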

Compound 4, half-maximal inhibitory concentration: 86100 nM
For compound 4 the middle estimate is 1.2-fold (0.06 log units) above the measured one, within the range that was stated.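

Compound 4 is the only one of the four shown to give a number rather than a limit in this assay, so this part of the series now has a value against which its neighbours can be set. On the aromatic carbon between two ring nitrogen atoms, the change to hydrogen gives an at least 1.1-fold lower number from compound 3 to compound 4 (0.06 log units; that floor lies within the scatter), while at the chloro-bearing carbon, the exchange of methylamino gives an at least 1.1-fold lower number from compound 2 to compound 4 (0.06 log units; that floor lies within the scatter) and the exchange of hydroxy gives an at least 1.1-fold lower number from compound 1 to compound 4 (0.06 log units; that floor lies within the scatter). All three are floors that stay within the scatter, so neither change is shown to matter, and the series as shown still sits at the edge of what this assay can read: the limit of > 100000 nM in this assay, at which 3 of the 4 values shown sit.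

From the compounds shown here alone, the true distance of compound 1, compound 2 and compound 3 from compound 4 remains unknown, and the step between compound 1 and compound 2 still cannot be read. Also open, going by these compounds, is whether a methoxy group or a longer chain such as propylamino on the chloro-bearing carbon would give a number clearly apart from that of compound 4.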